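Halogenated aryl variants and microsomal half-life

A few compounds are considered here, and "the series" means these few. Any claim that something is new, unique, unknown or untested is made for them only; others in the source may bear on it.

Compound 2 `Nc1nc(NCCNc2ncc(-c3ncc[nH]3)c(-c3ccc(F)cc3F)n2)ccc1[N+](=O)[O-]` is one of three analogues sharing the same core. In an ADME assay on microsomes from liver (Rattus norvegicus) for metabolic stability (on this read-out higher numbers stand for a longer-lived compound and lower numbers for a shorter-lived compound), compound 2 gives > 0.5 h, which is a limit of the assay and not a number. Compound 1 `N#Cc1ccc(-c2nc(NCCNc3ccc([N+](=O)[O-])c(N)n3)ncc2-c2ncc[nH]2)cc1` likewise gives only a limit in this assay, > 0.5 h. Compound 3 `Nc1nc(NCCNc2ncc(-c3ncc[nH]3)c(-c3ccc(Br)cc3Cl)n2)ccc1[N+](=O)[O-]` also gives a limit in this assay, > 0.5 h. All three sit at the limit of > 0.5 h in this assay, at which 3 of the 3 values shown sit, so the steps a step that the two limits leave unreadable from compound 1 to compound 2, a step that the two limits leave unreadable from compound 1 to compound 3 and a step that the two limits leave unreadable from compound 2 to compound 3 cannot be read in size or direction. Compound 4 `Nc1nc(NCCNc2ncc(-c3ncc[nH]3)c(-c3ccc(Cl)cc3Br)n2)ccc1[N+](=O)[O-]` differs from compound 2 by 2-bromo-4-chlorophenyl in place of 2,4-difluorophenyl on an aromatic carbon. The measured exchange of 2,4-difluorophenyl for 4-bromo-2-chlorophenyl is unreadable, so no step beyond the scatter can be expected. For compound 4 the estimated step is a step that the limit leaves unreadable from compound 2 to compound 4. Compound 4 is expected to give about 1 h in this assay, within 0.4 h to 3 h, most likely again as a limit.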

Compound 4, half-life: > 0.5 h
Compound 4: only a limit was reported; the forecaster's own chance of this, stated with the estimate: 75%; the middle value is on the limit's open side.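

The steps linking compound 4 to compound 1, compound 2 and compound 3 cannot be read in this assay, as each result is only a limit: the limit of > 0.5 h in this assay, at which 4 of the 4 values shown sit.

From the compounds shown here alone, the actual half-lives of all four compounds, and whether any of these aromatic exchanges changes them, remain open.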